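The source may report more compounds than this note shows. Statements on the series, on what has been measured and on what is new or still open speak of the compounds shown alone.

Measured compounds: compound 1 `COc1cc(/C=C/C(=O)c2cccc(-n3cc(-c4ccccc4)[nH]c3=O)c2)ccc1O` gives 1480 nM; compound 2 `COc1cc(/C=C/C(=O)c2cccc(-n3cc(-c4ccccc4)[nH]c3=O)c2)cc(OC)c1OC` gives 4120 nM; compound 3 `COc1ccc(-c2cn(-c3cccc(C(=O)/C=C/c4ccc(O)c(OC)c4)c3)c(=O)[nH]2)cc1` gives 5150 nM.

In a functional assay on HOP-62 cells (Homo sapiens) for inhibition (on this read-out lower numbers stand for stronger inhibition of growth and higher numbers for weaker inhibition of growth), compound 2 stands second highest of the three numbers: compound 3 lies within the scatter of it, while compound 1 lies beyond the scatter with a lower number. Compound 4 `COc1cc(/C=C/C(=O)c2cccc(-n3cc(-c4cc(OC)c(OC)c(OC)c4)[nH]c3=O)c2)cc(OC)c1OC` differs from compound 2 by 3,4,5-trimethoxyphenyl in place of phenyl on an aromatic carbon. Among the compounds with values here, the one measured step that bears on this change is a 3.5-fold higher number from compound 1 to compound 3 (0.54 log units; beyond the scatter), in which a methoxy enters on an aromatic carbon of the same phenyl. The trimethoxyphenyl of compound 4 carries more of that change, so a step in the same direction, toward a higher number in this assay, is expected, a 2.7-fold higher number from compound 2 to compound 4 (0.43 log units; beyond the scatter). Compound 4 is estimated at 11000 nM, with a range from 4500 nM to 28000 nM.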

Compound 4, concentration for 50% growth inhibition: 3080 nM
Compound 4: middle estimate off by 3.6-fold (0.55 log units), on the high side; the measured number lies below the stated range.
By their numbers in this assay, from the lowest: compound 1; then compounds 4, 2 and 3 (each within the scatter of the next).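

In this assay this place on the five-membered ring accepts 3,4,5-trimethoxyphenyl in place of phenyl with a 1.3-fold lower number from compound 2 to compound 4 (0.13 log units; within the scatter) and the two numbers stay within the scatter of each other. A single methoxy on the same phenyl, with a different group at the other end of the core, gave a 3.5-fold higher number from compound 1 to compound 3 (0.54 log units; beyond the scatter) so the rise seen there does not hold across this series. Nothing measured here accounts for the difference between these two steps.

Still open, from the compounds shown here alone, is how an amine or a carboxylic acid on this phenyl would read, and whether a single methoxy would also leave the number unmoved with the 3,4,5-trimethoxyphenyl end of the core in place.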